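The source may hold more compounds than are shown below. What is called first, only, known or untested is meant among the compounds shown, and "the series" means these compounds.

Measured in an in vitro ADME assay on microsomes (Homo sapiens) for metabolic stability; on this read-out lower numbers stand for a shorter-lived compound and higher numbers for a longer-lived compound:
- compound 1 `CNC(=O)Nc1ccc(-c2nc(N3CC4CCC(C3)O4)c3cnn(C(C)C)c3n2)cc1`: 0.2 h
- compound 2 `O=C(Nc1ccc(-c2nc(N3CC4CCC(C3)O4)c3cnn(C4CCC5(CC4)OCCO5)c3n2)cc1)Nc1cccnc1`: 0.217 h
- compound 3 `O=C(Nc1ccc(-c2nc(N3CC4CCC(C3)O4)c3cnn(C4CCC5(CC4)OCCO5)c3n2)cc1)NC1CC1`: 0.15 h

Compound 1 stands within the scatter of both compound 2 and compound 3. Compound 4 `CNC(=O)Nc1ccc(-c2nc(N3CC4CCC(C3)O4)c3cnn(C4CCC(OC)(OC)CC4)c3n2)cc1` is still unmeasured, and its change from compound 1 is a group of 10 heavy atoms (8 carbon, 2 oxygen; one six-membered non-aromatic ring of carbon only) in place of a group of 3 heavy atoms (3 carbon; no ring), on an aromatic nitrogen.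

Going by the values given here, no measured step covers this change. The only one, a 1.4-fold lower number from compound 2 to compound 3 (0.16 log units; within the scatter), lies elsewhere in the structure and stays within the scatter. Compound 2 and compound 3 also carry a group larger than isopropyl on that aromatic nitrogen, yet their values remain within the scatter of compound 1. No step beyond the scatter is therefore expected in this assay. The expected change is a 1.2-fold lower number from compound 1 to compound 4 (0.07 log units; within the scatter). For compound 4 the estimated value is 0.17 h, with an expected range of 0.09 h to 0.32 h.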

Compound 4, half-life: 0.5 h
Compound 4: middle estimate off by 2.9-fold (0.47 log units), on the low side, and the stated range ends below it.
By their numbers in this assay, from the lowest: compounds 3, 1 and 2 (each within the scatter of the next); then compound 4.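

In this assay, going by these compounds alone, the aromatic nitrogen of the five-membered ring proves to be a position where a change can move the number: the group of 10 heavy atoms in place of isopropyl gives a 2.5-fold higher number from compound 1 to compound 4 (0.40 log units; beyond the scatter) as the first step beyond the scatter. Within the data shown here, no earlier pair isolated a change at this position. No measurement on hand accounts for this step.

Open, going by these compounds, is whether the six-membered ring of carbon or the oxygen atoms of the entering group carry the step; plain cyclohexyl on that nitrogen would separate the two. Also open, on these data alone, is whether the step holds with cyclopropyl or pyridin-3-yl on the amide-type nitrogen.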